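This account rests on a few compounds, and the source may have more. Where it says the series, first, only, none or still open, it means among the compounds named here.

Compound 1 `C=CCCC(=O)N[C@H]1[C@@H](OCCc2ccccc2)O[C@H](CO)[C@@H](O)[C@@H]1O` is the starting point. In a functional assay on U-373MG ATCC cells (Homo sapiens), read by thymidine incorporation (a lower number here means a stronger inhibitor, a higher number a weaker inhibitor), compound 1 gives > 50 uM, which is a limit of the assay rather than a number. Compound 2 `C=CCCC(=O)N[C@H]1[C@@H](OCCc2ccccc2)O[C@H](CO)[C@@H](O)[C@@H]1OS(=O)(=O)O` gives > 50 uM in this assay, also a limit. The step that the two limits leave unreadable from compound 1 to compound 2 is therefore not readable, because of the limit of > 50 uM in this assay, at which 2 of the 2 values shown sit. Compound 3 `C=CCCC(=O)N[C@H]1[C@@H](OCCc2ccccc2)O[C@H](COS(=O)(=O)O)[C@@H](O)[C@@H]1O` differs from compound 1 by sulfo in place of hydrogen on an oxygen on a saturated carbon. For the measured compounds named here, the single measured step, a sulfo group entering at another oxygen, gave no readable size, so no change beyond the scatter is expected. Compound 3 is expected to give 100 uM in this assay, between 30 uM and 500 uM. This means an expected step that the limit leaves unreadable from compound 1 to compound 3.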

Compound 3, concentration for 50% inhibition: > 50 uM
Compound 3 gave a limit, no number; the forecaster's own chance of this, stated with the estimate: 85%; the middle value lies beyond the limit too.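

The size of the step from compound 1 to compound 3 cannot be read, because both compounds give only a limit, not a number: the limit of > 50 uM in this assay, at which 3 of the 3 values shown sit.

Still open, as far as these compounds go, is how strongly compound 1, compound 2 or compound 3 inhibits in this assay, and so whether a sulfo group changes that at either oxygen.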